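The source may hold more compounds than are shown below. What is called first, only, known or untested is meant among the compounds shown, and "the series" means these compounds.

The measured compounds are compound 1 `CSc1nc2cnsc2n1[C@H]1C[C@H](O)[C@@H](CO)O1`, compound 2 `OC[C@H]1O[C@@H](n2c(SCc3ccccc3)nc3cnsc32)C[C@@H]1O` and compound 3 `CSc1nc2sncc2n1[C@H]1C[C@H](O)[C@@H](CO)O1`; compound 4 `OC[C@H]1O[C@@H](n2c(SCc3ccccc3)nc3sncc32)C[C@@H]1O` has not yet been measured.

In a functional assay on L1210 cells (Mus musculus) for antiproliferative activity (on this read-out higher numbers stand for weaker inhibition and lower numbers for stronger inhibition), compound 1 gives > 100000 nM, which is a limit of the assay and not a number. In this assay compound 2 gives 8000 nM, and compound 3 gives 20000 nM. Compounds 1 and 3 are built from the same atoms joined differently; the difference between the two cores is not broken down here. Compound 3 stands highest of the two numbers, with compound 2 nearest.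

The change from compound 1 to compound 2 is phenyl in place of hydrogen on a saturated chain carbon bound to a sulfur. It produced an at least 12-fold lower number from compound 1 to compound 2 (1.09 log units; beyond the scatter), and the size of that step is bounded by the limit of > 100000 nM in this assay, at which 1 of the 3 values shown sits, so only its lower edge is known.

Compound 4 carries the same change on the core of compound 3: phenyl in place of hydrogen on a saturated chain carbon bound to a sulfur. The two places read word for word alike, so the change is the same. Within the data shown here, since the one measured instance of this change gave an at least 12-fold lower number from compound 1 to compound 2 (1.09 log units; beyond the scatter), the step from compound 3 to compound 4 in this assay is expected to be of comparable size, estimated as a 13-fold lower number from compound 3 to compound 4 (1.12 log units; beyond the scatter). In this assay compound 4 is therefore expected to give about 1500 nM, most likely between 300 nM and 8000 nM.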

Compound 4, half-maximal inhibitory concentration: 2200 nM
Compound 4: the middle estimate sits 1.5-fold (0.17 log units) below what was measured; the range from low to high includes it.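

In this assay the change from methylsulfanyl to benzylsulfanyl carried over to the core of compound 3 and went the same way there, with a 9.1-fold lower number from compound 3 to compound 4 (0.96 log units; beyond the scatter). Set beside the earlier step on the core of compound 1, the comparison reads: the same change on two cores in this assay, an at least 12-fold lower number (1.09 log units; beyond the scatter) from compound 1 to compound 2 and a 9.1-fold lower number (0.96 log units; beyond the scatter) from compound 3 to compound 4; the limit leaves it open whether they differ. Among these compounds, this shows that the lower number followed the change on both cores, but these are only two cores, and it does not show that the two steps are equal in size, since one of them has only a lower edge: the limit of > 100000 nM in this assay, at which 1 of the 4 values shown sits.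

As far as these compounds go, what an ethyl group or a longer chain on the sulfur would do on either core remains open, as does the effect of a phenyl ring carrying an amine or a carboxylic acid. The compounds shown also leave open whether the change would carry over to a core beyond these two, or whether the same direction would appear in any read-out other than this assay.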